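Cytotoxicity of a chalcone-amide series on Vero cells

This account rests on a few compounds, and the source may have more. Where it says the series, first, only, none or still open, it means among the compounds named here.

Measured compounds:
compound 1 `COC(=O)c1cc(-c2cccc(NC(=O)c3ccc(/C=C/C(=O)c4ccccc4)cc3)c2)on1`, > 50 ug/mL
compound 2 `COC(=O)c1cc(-c2cccc(NC(=O)c3ccc(/C=C/C(=O)c4cc(OC)c(OC)c(OC)c4)cc3)c2)on1`, > 50 ug/mL
compound 3 `COC(=O)c1cc(-c2cccc(NC(=O)c3ccc(/C=C/C(=O)c4cc(F)ccc4F)cc3)c2)on1`, > 40 ug/mL

In an ADME assay on Vero cells (Chlorocebus sabaeus) for cytotoxicity, read by MTT assay, with a stated time of 72 h (a higher number here means that more compound is tolerated, a lower number that less compound is tolerated), compound 1 gives > 50 ug/mL, which is a limit of the assay and not a number. Compound 2 likewise gives > 50 ug/mL, also a limit. Compound 3 gives > 40 ug/mL, again a limit. So compound 1 stands at a limit, and the two further values shown are limits too: the limit of > 50 ug/mL in this assay, at which 2 of the 3 values shown sit, and (the limit of > 40 ug/mL in this assay, at which 1 of the 3 values shown sits).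

The unmeasured compound 4 `COC(=O)c1cc(-c2cccc(NC(=O)c3ccc(/C=C/C(=O)c4ccc(C)c(F)c4)cc3)c2)on1` differs from compound 1 in one place: 3-fluoro-4-methylphenyl in place of phenyl on a carbonyl carbon. Among the compounds with values here, the steps that bear on this change all alter the same aryl group on the carbonyl carbon: a step that the two limits leave unreadable from compound 1 to compound 2, a step that the two limits leave unreadable from compound 1 to compound 3 and a step that the two limits leave unreadable from compound 2 to compound 3. None of them can be read, so they give no direction or size. Because every value sits at a limit (the limit of > 50 ug/mL in this assay, at which 2 of the 3 values shown sit), compound 4 is expected to behave in the same way, with no step beyond the scatter, a step that the limit leaves unreadable from compound 1 to compound 4. Compound 4 is therefore estimated at 60 ug/mL, between 40 ug/mL and 100 ug/mL.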

Compound 4, half-maximal cytotoxic concentration: > 50 ug/mL
Compound 4: only a limit was reported; the forecaster's own chance of this, stated with the estimate: 85%; the middle value does not contradict the limit.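

In this assay compound 4 gives > 50 ug/mL, which is a limit of the assay and not a number. Compound 1, compound 2 and compound 3 also stand at limits, so none of the steps to compound 4 can be read. The compounds shown leave open whether the aryl group on the carbonyl carbon alters tolerance at all.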